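Swapping the basic side group on a urea-linked aryl ring

The compounds below may be only part of what the source reports. "The series", "measured", "known", "first", "only" and "open" are said of these compounds alone.

Compound 1 `CN(C)Cc1ccc(NC(=O)Nc2ccc3ncnc(Nc4cccc(C(F)(F)F)c4)c3c2)cc1` carries a shared core with a trifluoromethyl-substituted aniline at one end and a urea-linked aryl ring at the other. Going by the values given here, in a functional assay on A-431 cells (Homo sapiens) for antiproliferative activity, read by MTT assay, with a stated time of 72 h (a higher number here means a weaker inhibitor, a lower number a stronger inhibitor), compound 1 gives 1030 nM, the lowest of the two numbers so far, though the other one sits close by. Compound 2 `O=C(Nc1cccc(CN2CCCC2)c1)Nc1ccc2ncnc(Nc3cccc(C(F)(F)F)c3)c2c1` differs only in the urea-linked ring, and in this assay compound 2 gives 1230 nM; the step of a 1.2-fold higher number from compound 1 to compound 2 (0.08 log units; within the scatter) is within the scatter, so the two compounds cannot be told apart on this read-out.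

Compound 3 `CN1CCN(c2ccc(NC(=O)Nc3ccc4ncnc(Nc5cccc(C(F)(F)F)c5)c4c3)cc2)CC1` is the next variation: 4-methylpiperazin-1-yl in place of (dimethylamino)methyl on an aromatic carbon. Among the compounds with values here, the only measured step that bears on this, a 1.2-fold higher number from compound 1 to compound 2 (0.08 log units; within the scatter), also exchanged one basic side group for another on that same ring and produced no change beyond the scatter. On that basis a step of about a 1.2-fold higher number from compound 1 to compound 3 (0.07 log units; within the scatter) is expected, which is to say essentially none. The estimate for compound 3 in this assay is therefore 1200 nM, with a plausible range from 400 nM to 3600 nM.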

Compound 3, half-maximal inhibitory concentration: 2200 nM
Compound 3: middle estimate off by 1.8-fold (0.26 log units), on the low side; the range from low to high includes it.
By their numbers in this assay, from the lowest: compounds 1, 2 and 3 (each within the scatter of the next, the first and the last beyond it).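

Putting 4-methylpiperazin-1-yl in place of (dimethylamino)methyl on this aromatic carbon gives, in this assay, a 2.1-fold higher number from compound 1 to compound 3 (0.33 log units; beyond the scatter), a modest step but the first in the series to pass the scatter, so the read-out does respond to what is attached to this ring. The earlier swap, a 1.2-fold higher number from compound 1 to compound 2 (0.08 log units; within the scatter), stayed within the scatter, which shows that exchanging one amine-bearing side group for another does not always produce a readable change, although that swap also involved a different ring position. No measurement here explains why the 4-methylpiperazin-1-yl group gives the higher number.

The change from compound 1 to compound 3 adds heavy atoms and a six-membered non-aromatic ring together, so these compounds cannot show which of the two goes with the step, and a morpholin-4-yl ring or a longer chain carrying the dimethylamino group at the same carbon could help separate them. From the compounds shown here alone, whether an amine is needed at this place at all also remains open, a question that a hydroxyl group or a carboxylic acid there could address.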